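A few compounds are considered here, and "the series" means these few. Any claim that something is new, unique, unknown or untested is made for them only; others in the source may bear on it.

Working notes on the series. The shared core is kept throughout; what varies is the group on a saturated chain carbon bound to a nitrogen on an aromatic ring. Compound 1 `Cc1cc(NCc2ncccn2)n2nc(C)c(-c3ccccc3)c2n1` carries pyrimidin-2-yl there; in a physicochemical assay for solubility, read by HPLC, using the shake flask method, measured as kinetic solubility, with a stated time of 2 h, at pH 7.4 (a higher number here means a more soluble compound, a lower number a less soluble compound), compound 1 gives 37900 nM. Compound 2 `Cc1cc(NCc2c[nH]cn2)n2nc(C)c(-c3ccccc3)c2n1` carries 1H-imidazol-4-yl; in this assay compound 2 gives 14600 nM. Compound 3 `Cc1cccc(CNc2cc(C)nc3c(-c4ccccc4)c(C)nn23)n1` carries 6-methylpyridin-2-yl. In this assay compound 3 is reported only as a limit, < 5000 nM, which is the limit of < 5000 nM in this assay, at which 1 of the 3 values shown sits. The measured steps read a 2.6-fold lower number from compound 1 to compound 2 (0.41 log units; beyond the scatter), an at least 7.5-fold lower number from compound 1 to compound 3 (0.87 log units; beyond the scatter) and an at least 2.9-fold lower number from compound 2 to compound 3 (0.46 log units; beyond the scatter), so compound 3 stands at the low end of the three, with only a bound and no number.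

Compound 4 `CCN1CCCC1CNc1cc(C)nc2c(-c3ccccc3)c(C)nn12` differs from compound 3 in one place: 1-ethylpyrrolidin-2-yl in place of 6-methylpyridin-2-yl on a saturated chain carbon bound to a nitrogen on an aromatic ring. Among the measured compounds shown here, none of the measured steps exchanges an aromatic ring for a non-aromatic one, so they fix the starting point of compound 3 but give no size for this step. In this assay the step is expected to read an at least 6.0-fold higher number from compound 3 to compound 4 (0.77 log units; beyond the scatter), upward and wide in uncertainty. Compound 4 is therefore estimated at 30000 nM, between 5000 nM and 150000 nM.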

Compound 4, solubility: 172000 nM
Beside the measured number, compound 4's estimate is 5.7-fold (0.76 log units) below it, outside the stated range (above it).
By their numbers in this assay, from the lowest: compound 2; then compound 1; then compound 4. At a limit, below all of these: compound 3.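

Among the compounds shown here, at this place, on a saturated chain carbon bound to a nitrogen on an aromatic ring, 1-ethylpyrrolidin-2-yl is the first non-aromatic group, and in this assay it gives the highest number of the series, with a 12-fold higher number from compound 2 to compound 4 (1.07 log units; beyond the scatter) and a 4.5-fold higher number from compound 1 to compound 4 (0.66 log units; beyond the scatter). The exchange for 6-methylpyridin-2-yl leaves the counts of heavy atoms, donors and acceptors unchanged and replaces a six-membered aromatic ring with a five-membered non-aromatic ring, yet it reads an at least 34-fold higher number from compound 3 to compound 4 (1.53 log units; beyond the scatter). That step is only a bound, since compound 3 is held at a limit: the limit of < 5000 nM in this assay, at which 1 of the 4 values shown sits.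

The compounds shown leave open whether the higher number goes with the non-aromatic ring itself or with the ethyl on its nitrogen. A pyrrolidin-2-yl without the ethyl, a piperidin-2-yl or an open-chain diethylamine at this place would separate these readings.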